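This account rests on a few compounds, and the source may have more. Where it says the series, first, only, none or still open, it means among the compounds named here.

Three compounds built on one shared core have been run through an ADME assay on microsomes from liver (Mus musculus, strain NMRI) for metabolic stability, tested at 2.5 uM; on this read-out lower numbers stand for slow clearance and higher numbers for fast clearance. Compound 1, `Fc1ccccc1Cn1nnc2c(Br)cccc21`, gives 1.7 mL/min/g in this assay. Compound 2, `Clc1ccc(Cn2nnc3c(Br)cccc32)cc1`, gives 2 mL/min/g in this assay. Compound 3, `Fc1cc(Cn2nnc3c(Br)cccc32)ccc1Cl`, gives 2.2 mL/min/g in this assay. On these numbers compound 2 sits close to both neighbours: its gap to compound 3 and its gap to compound 1 each lie within the usual scatter of this assay, so no ordering among the three can be claimed.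

Compound 4, `Fc1cc(Cl)ccc1Cn1nnc2c(Br)cccc21`, has not yet been measured. It arises from compound 2 by one change: fluoro in place of hydrogen on an aromatic carbon. Among the measured compounds shown here, one measured step bears on this change, the same kind of swap made elsewhere on the same benzyl ring, which gave a 1.1-fold higher number from compound 2 to compound 3 (0.04 log units; within the scatter). That step lay inside the scatter, so a fluoro added in the new place is expected to leave the number close to that of compound 2, with no step beyond the scatter. Compound 4 is therefore estimated at 2 mL/min/g, with a range from 1.4 mL/min/g to 2.9 mL/min/g, meaning an expected step of no change at the digits printed from compound 2 to compound 4 (within the scatter).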

Compound 4, intrinsic clearance in a liver preparation (reported as CLH), per the amount of preparation that the assay uses: 1.3 mL/min/g
Compound 4: middle estimate off by 1.5-fold (0.19 log units), on the high side, outside the stated range (below it).
By their numbers in this assay, from the lowest: compounds 4, 1, 2 and 3 (each within the scatter of the next).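

In this assay, placing a fluoro on the aromatic carbon ortho to a large group and meta to the chloro group gives a 1.5-fold lower number from compound 2 to compound 4 (0.19 log units; within the scatter). Read the other way, adding the chloro group to the fluoro-bearing benzyl ring gives a 1.3-fold lower number from compound 1 to compound 4 (0.12 log units; within the scatter), so compound 4 shows that this ring can carry both halogens together with no change in clearance that stands clear of the scatter. No measurement shown here offers an explanation for these small differences.

On these data alone, what remains open is whether a larger group in the same place, such as methoxy or trifluoromethyl, would shift clearance beyond the scatter. An amine or a carboxylic acid there is equally open, as the compounds shown carry only halogens on this ring.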